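Swapping the aryl group on the oxadiazole of an acyl-coenzyme A oxidase inhibitor

The compounds below may be only part of what the source reports. "The series", "measured", "known", "first", "only" and "open" are said of these compounds alone.

For the measured compounds named here, compound 2 `Cc1nc2cc(OC[C@H](O)CN3CCN(Cc4noc(-c5ccc(Cl)cc5Cl)n4)CC3)ccc2s1` gives 130 nM in a functional assay on mitochondria from heart for inhibition of peroxisomal acyl-coenzyme A oxidase 1 (Rattus norvegicus) (a lower number here means a stronger inhibitor, a higher number a weaker inhibitor), and holds the lowest of the two numbers measured so far. Its nearest neighbour is compound 1 `Cc1nc2cc(OC[C@H](O)CN3CCN(Cc4noc(-c5ccc(C(C)C)cc5)n4)CC3)ccc2s1`, which in this assay gives 950 nM. Going by the values given here, the one step between measured compounds, a 7.3-fold lower number from compound 1 to compound 2 (0.86 log units; beyond the scatter), shows that the group on the oxadiazole carbon alone can move the read-out well beyond the scatter. Compound 3 `Cc1nc2cc(OC[C@H](O)CN3CCN(Cc4noc(-c5ccc(C#N)cc5)n4)CC3)ccc2s1` differs from compound 2 only there: 4-cyanophenyl in place of 2,4-dichlorophenyl on an aromatic carbon. Among the compounds with values here, no measured pair covers a 4-cyanophenyl, so the direction rests on the single step seen. Because compound 1 with its 4-isopropylphenyl already gives 950 nM, a change away from the 2,4-dichlorophenyl is expected to raise the number, by roughly a 4.6-fold higher number from compound 2 to compound 3 (0.66 log units; beyond the scatter). Compound 3 is therefore estimated at 600 nM, with a range from 150 nM to 2500 nM.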

Compound 3, half-maximal inhibitory concentration: 4410 nM
Beside the measured number, compound 3's estimate is 7.4-fold (0.87 log units) below it, and the stated range ends below it.
By their numbers in this assay, from the lowest: compound 2; then compound 1; then compound 3.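

The aryl group on the oxadiazole carbon turns out to matter more than the first pair suggested: the change from 2,4-dichlorophenyl to 4-cyanophenyl gives a 34-fold higher number from compound 2 to compound 3 (1.53 log units; beyond the scatter), even though 8 heavy atoms leave and 8 enter. The 4-cyanophenyl also compares poorly with the 4-isopropylphenyl, with a 4.6-fold higher number from compound 1 to compound 3 (0.67 log units; beyond the scatter), which makes compound 3 the weakest inhibitor of the three and compound 2 the strongest. No measurement at hand explains this order.

The compounds shown do not separate the two chlorines of compound 2, so a 4-chlorophenyl and a 2-chlorophenyl would be needed to tell which one goes with its low number. Going by these compounds, it also remains open where a plain phenyl or a 4-methoxyphenyl would fall in this order.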